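Swapping Hydroxy for a Larger Carbamoyl Group

The compounds below may be only part of what the source reports. "The series", "measured", "known", "first", "only" and "open" are said of these compounds alone.

Going by the values given here, this series shares one core, and its only firm number comes from a functional assay on A2058 cells (Homo sapiens) for antiproliferative activity, read by luminescence and CellTiter-Glo, with a stated time of 96 h; a higher number here means a weaker inhibitor, a lower number a stronger inhibitor. There, compound 1 `NC(=O)c1ccc(-c2ccc(F)c(C(=O)Nc3c[nH]nc3C(=O)Nc3ccc(F)cc3)c2F)cn1` gives 295 nM. Compound 2 `COC(=O)c1cccc(-c2ccc(F)c(C(=O)Nc3c[nH]nc3C(=O)Nc3ccc(F)cc3)c2F)c1` stands at "not determined" (no result reported). Compound 3 `O=C(Nc1ccc(F)cc1)c1n[nH]cc1NC(=O)c1c(F)ccc(-c2cccc(O)c2)c1F` stands at "not determined" (no result reported), so it offers no number to start from. Compound 4 `CN1CCC(CNC(=O)c2cccc(-c3ccc(F)c(C(=O)Nc4c[nH]nc4C(=O)Nc4ccc(F)cc4)c3F)c2)CC1` has yet to be measured. Its structure differs as follows: ((1-methylpiperidin-4-yl)methyl)carbamoyl in place of hydroxy on an aromatic carbon. That places ((1-methylpiperidin-4-yl)methyl)carbamoyl in place of hydroxy on an aromatic carbon. Among the compounds with values here, with no measured step to lean on, the only guide is compound 1 at 295 nM, and no step beyond the usual scatter from that level is expected in this assay. Compound 4 is expected at about 200 nM, within an estimated range of 40 nM to 1000 nM.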

Compound 4, half-maximal inhibitory concentration: 3340 nM
For compound 4 the middle estimate is 17-fold (1.22 log units) below the measured one; the measured number lies above the stated range.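

Going by these compounds alone, compound 3 offers no number to set against compound 4, so no step between them can be read. From the compounds shown here alone, what replacing hydroxy with ((1-methylpiperidin-4-yl)methyl)carbamoyl does to activity stays open. Nothing shown accounts for the value of compound 4.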